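A few compounds are considered here, and "the series" means these few. Any claim that something is new, unique, unknown or untested is made for them only; others in the source may bear on it.

The three compounds share one core and differ at the pyridine attached through the ether oxygen or at the nitrogen of the fused ring. Compound 2 `CC(=O)Nc1cc(Oc2ccc(Nc3nccc4[nH]cc(-c5ccc(F)cc5)c(=O)c34)cc2F)ccn1` gives 36.8% in a functional assay on HT-29 cells (Homo sapiens) for antiproliferative activity, read by MTT assay, with a stated time of 72 h, tested at 10 uM (a higher number here means more inhibition at the concentration tested (going by the name of the read-out), a lower number less inhibition), the highest of the three numbers. Compound 1 `Cn1cc(-c2ccc(F)cc2)c(=O)c2c(Nc3ccc(Oc4ccnc(NC(=O)C5CC5)c4)c(F)c3)nccc21` gives 24.8% in this assay, and compound 3 `CCCCC(=O)Nc1cc(Oc2ccc(Nc3nccc4[nH]cc(-c5ccc(F)cc5)c(=O)c34)cc2F)ccn1` gives -42.2%. Compound 1 differs from compound 2 in two places, so only the two values themselves can be compared. Within the data shown here, the one single-point step, a number 79 percentage points lower from compound 2 to compound 3 (beyond the scatter), shows that enlarging the acyl group on the pyridine amide costs the whole of the inhibition. The step to compound 4 `Nc1nccc(Oc2ccc(Nc3nccc4[nH]cc(-c5ccc(F)cc5)c(=O)c34)cc2F)c1Cl` is different: 2-amino-3-chloropyridin-4-yl in place of 2-acetamidopyridin-4-yl on an oxygen on an aromatic ring. The acyl group is removed rather than enlarged, and a chlorine enters on the ring. The step from compound 2 to compound 3 bears on it only in showing that this position is sensitive; the direction of a smaller, differently shaped change is not settled. Compound 4 is therefore expected to move a number 16.8 percentage points lower from compound 2 to compound 4 (beyond the scatter), with an estimated 20% in this assay, within a range from -20% to 50%.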

Compound 4, a percentage reported as inhibition, at one concentration (the size of the read-out at that concentration, not a potency): 56.2%
Compound 4: middle estimate off by 36.2 percentage points, on the low side, outside the stated range (above it).
By their numbers in this assay, from the lowest: compound 3; then compound 1; then compound 2; then compound 4.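

In this assay, replacing 2-acetamidopyridin-4-yl with 2-amino-3-chloropyridin-4-yl on an oxygen on an aromatic ring gives a number 19.4 percentage points higher from compound 2 to compound 4 (beyond the scatter), so a change at this position can raise the number as well as lower it. The earlier single-place step, a number 79 percentage points lower from compound 2 to compound 3 (beyond the scatter), ran downward on enlarging the acyl group, whereas this new step shows that the acetamide of compound 2 is not needed for inhibition at the concentration tested. No evidence is available on why the number rises.

This step removes the acyl group and brings in a chlorine together, so the compounds shown cannot tell which of the two changes accounts for the rise. The pyridine carrying the free amine without the chlorine, or the acetamide with the chlorine, would separate them, and a methyl group in place of the chlorine remains an open case.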